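The source may report more compounds than this note shows. Statements on the series, on what has been measured and on what is new or still open speak of the compounds shown alone.

Measured compounds:
Compound 1, `CCn1c(SCC(=O)c2ccccc2)nnc1-c1ccc(OC)cc1`: 70%
Compound 2, `C=CCn1c(SCC(=O)c2ccccc2)nnc1-c1ccc(OC)cc1`: 67%
Compound 3, `CCn1c(SC/C(=N/O)c2ccccc2)nnc1-c1cc(OC)c(OC)c(OC)c1`: 79%

All three were tested in a functional assay on the whole organism (strain albino) for inhibition, with Rattus norvegicus as the target, read by paw edema, with a stated time of 4 h, at a dose of 0.28 mmol/kg by the oral route; a lower number here means less inhibition, a higher number more inhibition at the dose given (going by the name of the read-out). Compound 1 and compound 2 share one core and differ only by vinyl in place of methyl on a saturated chain carbon bound to an aromatic nitrogen; that change gave a number 3 percentage points lower from compound 1 to compound 2 (within the scatter). Compound 3 is built on a different core, and the difference between the two cores is not broken down here. In this assay compound 3 gives 79%, close to compound 1 and somewhat further from compound 2.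

Compound 4, `C=CCn1c(SC/C(=N/O)c2ccccc2)nnc1-c1cc(OC)c(OC)c(OC)c1`, has not been measured. It differs from compound 3 by vinyl in place of methyl on a saturated chain carbon bound to an aromatic nitrogen, the same change as from compound 1 to compound 2, made on the same kind of position. Since the measured instance of this change, a number 3 percentage points lower from compound 1 to compound 2 (within the scatter), stayed within the scatter, the step from compound 3 to compound 4 is expected to be similar in size, a number 3 percentage points lower from compound 3 to compound 4 (within the scatter), because compound 3 starts from 79%. On this basis compound 4 is expected to give about 76%, with a range from 62% to 88%.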

Compound 4, a percentage reported as inhibition, in the whole organism at one dose (the size of the read-out at that dose, not a potency): 73%
The estimate for compound 4 lay 3 percentage points above the measured number, within the range that was stated.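

In this assay, going by these compounds alone, the change from ethyl to allyl gave a number 6 percentage points lower from compound 3 to compound 4 (within the scatter), so on the core of compound 3 it again produced no step that stands out from the usual variation. Set beside the earlier step, the change carries across the two cores without a detectable difference: the same change on two cores in this assay, a number 3 percentage points lower (within the scatter) from compound 1 to compound 2 and a number 6 percentage points lower (within the scatter) from compound 3 to compound 4, 3 percentage points apart, within the scatter of two such steps. Within the data shown here, this shows only that the change stayed small on both of these cores at a single oral dose and a single time point; it does not show that the step is the same size on other cores, or that the change would behave this way at other doses, since one dose gives the size of a read-out and not a potency.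

The compounds shown leave open whether a longer chain such as butyl, or a benzyl group, in the same place would also leave the reading in this assay undisturbed. They also leave open how an amine or a carboxylic acid at that place would read.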